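The compounds below may be only part of what the source reports. "The series", "measured", "known", "first", "only" and "open" are said of these compounds alone.

In a functional assay on MOLT-4 cells (Homo sapiens) for cytotoxicity, read by CCK-8 assay, with a stated time of 24 h (on this read-out higher numbers stand for weaker inhibition and lower numbers for stronger inhibition), compound 3 `C=CC(=O)N1C(=O)CC(c2ccccc2)Sc2ccccc21` gives 85900 nM. Compound 1 `C=CC(=O)N1C(=O)CC(c2ccc(OC)cc2)Sc2ccccc21` gives 83200 nM, within the scatter of compound 3, while compound 2 `C=CC(=O)N1C(=O)CC(C)Sc2ccccc21` gives 730000 nM, the highest number of the three.

The next change leads to compound 4 `C=CC(=O)N1C(=O)CC(c2ccc(C#N)cc2)Sc2ccccc21`: cyano in place of hydrogen on an aromatic carbon, para to a large group (cyano in place of hydrogen on an aromatic carbon).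

The closest measured precedent is a 1.0-fold higher number from compound 1 to compound 3 (0.01 log units; within the scatter), with hydrogen in place of methoxy on an aromatic carbon. The two larger steps, an 8.8-fold higher number from compound 1 to compound 2 (0.94 log units; beyond the scatter) and an 8.5-fold lower number from compound 2 to compound 3 (0.93 log units; beyond the scatter), instead exchange the whole aromatic group for methyl or the reverse, and compound 4 keeps that aromatic ring. Methoxy is the only group measured on that ring so far, so this precedent is thin, and cyano there remains untested.

The expected outcome is a 1.1-fold lower number from compound 3 to compound 4 (0.03 log units; within the scatter), with no shift beyond the scatter anticipated in this assay. For compound 4 the estimated value is 80000 nM, with an expected range of 38000 nM to 170000 nM.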

Compound 4, half-maximal inhibitory concentration: 88700 nM
The estimate for compound 4 lay 1.1-fold (0.04 log units) below the measured number; measured number inside the range.
By their numbers in this assay, from the lowest: compounds 1, 3 and 4 (each within the scatter of the next); then compound 2.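

In this assay the step with cyano in place of hydrogen gives a 1.0-fold higher number from compound 3 to compound 4 (0.01 log units; within the scatter) and the step with cyano in place of methoxy gives a 1.1-fold higher number from compound 1 to compound 4 (0.03 log units; within the scatter) so hydrogen, methoxy and cyano at this place on the aromatic ring cannot be told apart in this series. Compound 4 thereby joins compounds 1 and 3, each lying beyond the scatter from compound 2, which carries methyl instead of an aromatic group (the step with 4-cyanophenyl in place of methyl gives an 8.2-fold lower number from compound 2 to compound 4 (0.92 log units; beyond the scatter)). No supporting data bear on why the three ring substituents leave the number unmoved.

On these data alone, whether an amine or a carboxylic acid at this ring position would separate from these three remains open. As far as these compounds go, a longer chain in place of methyl on the saturated ring carbon also remains open, so the span between methyl and the aromatic groups has no intermediate point.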